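The source may hold more compounds than are shown below. What is called first, only, known or untested is meant among the compounds shown, and "the series" means these compounds.

The measured compounds so far:

Compound 1 `CC1=NC(C)=C([N+](=O)[O-])C(c2ccncc2)/C1=C(\O)OC(C)(C)C` gives 2820 nM in a functional assay (cardiac atrium) for agonist activity, with Cavia porcellus as the target; on this read-out lower numbers stand for an effect already at smaller amounts and higher numbers for an effect only at larger amounts of compound.
Compound 2 `CC1=NC(C)=C([N+](=O)[O-])C(c2ccncc2)/C1=C(\O)OC1CCCCC1` gives 4940 nM in this assay.

For the measured compounds named here, compound 2 holds the highest of these two numbers in this assay; its only neighbour is compound 1, and the step between them, a 1.8-fold higher number from compound 1 to compound 2 (0.24 log units; within the scatter), stays within the scatter, so the two compounds cannot be ordered on these data. Compound 3 `CC1=NC(C)=C([N+](=O)[O-])C(c2ccncc2)/C1=C(\O)OC(C)C` differs from compound 2 by isopropyl in place of cyclohexyl on an oxygen on an unsaturated carbon. Going by the values given here, the one measured step that bears on this change is a 1.8-fold higher number from compound 1 to compound 2 (0.24 log units; within the scatter), a swap of the group on the same oxygen on an unsaturated carbon, and it produced nothing beyond the scatter. Among the compounds with values here, no measured compound carries an isopropyl group at that place, so the expectation rests on that single step alone: the account expects no step beyond the scatter in this assay, namely a 1.4-fold lower number from compound 2 to compound 3 (0.15 log units; within the scatter). Compound 3 is therefore estimated at 3500 nM, with a range from 1200 nM to 10000 nM.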

Compound 3, half-maximal effective concentration: 8050 nM
Compound 3: middle estimate off by 2.3-fold (0.36 log units), on the low side; low and high end bracket the measured number.
By their numbers in this assay, from the lowest: compounds 1, 2 and 3 (each within the scatter of the next, the first and the last beyond it).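

For the compounds shown here, exchanging cyclohexyl for isopropyl on this oxygen stays within the scatter in this assay (a 1.6-fold higher number from compound 2 to compound 3 (0.21 log units; within the scatter)), but hydrogen in place of methyl on the saturated chain carbon, which turns the tert-butyl of compound 1 into isopropyl, gives the first step beyond the scatter at this place, though a modest one (a 2.9-fold higher number from compound 1 to compound 3 (0.46 log units; beyond the scatter)). The position is therefore not wholly indifferent to the group on this oxygen, yet no trend with group size can be drawn, as compound 2, which carries the largest group, lies within the scatter of both other compounds. No supporting measurement bears on this difference. The compounds shown leave open how a methyl, a longer straight chain such as butyl, or a chain ending in an amine would behave on this oxygen. They also leave open whether a cyclopentyl ring would stay within the scatter of the cyclohexyl of compound 2.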